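Swapping the chain on the thiadiazole amine: compound 3

This account rests on a few compounds, and the source may have more. Where it says the series, first, only, none or still open, it means among the compounds named here.

Among the measured compounds shown here, the two compounds measured so far share one core and differ only in the chain on a nitrogen of that core. Compound 1 `CCCCNc1nnc(SCC(=O)N(Cc2cccc([N+](=O)[O-])c2)c2ccc(F)cc2)s1` carries a butyl chain and in an assay on isolated protein for inhibition of Amine oxidase [flavin-containing] A (Homo sapiens), read by fluorescence and Amplex Red, with a stated time of 30 min, tested at 0.1 nM (on this read-out higher numbers stand for a stronger effect at the one concentration tested and lower numbers for a weaker effect), gives 11.1%. Compound 2 `COCCNc1nnc(SCC(=O)N(Cc2cccc([N+](=O)[O-])c2)c2ccc(F)cc2)s1` carries a 2-methoxyethyl chain and in this assay gives 20.1%. Of these two numbers compound 2 stands at the upper one, yet the step of a number 9 percentage points higher from compound 1 to compound 2 (within the scatter) lies within the scatter, so the two compounds cannot really be told apart on this read-out.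

Compound 3 `CC(C)Nc1nnc(SCC(=O)N(Cc2cccc([N+](=O)[O-])c2)c2ccc(F)cc2)s1` is the next variation: isopropyl in place of 2-methoxyethyl on a nitrogen on an aromatic ring. For the measured compounds named here, the only measured step, a number 9 percentage points higher from compound 1 to compound 2 (within the scatter), changed the same chain and moved the number by an amount no larger than the scatter, so a further swap of that chain is not expected to produce a step beyond the scatter in either direction.

Compound 3 is therefore estimated to give 14% in this assay, with a range from 2% to 27%, which amounts to an expected step of a number 6.1 percentage points lower from compound 2 to compound 3 (within the scatter).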

Compound 3, a percentage reported as inhibition, at one concentration (the size of the read-out at that concentration, not a potency): 10.8%
The estimate for compound 3 lay 3.2 percentage points above the measured number, within the range that was stated.
By their numbers in this assay, from the lowest: compounds 3, 1 and 2 (each within the scatter of the next).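

Across the three chains tried so far on this nitrogen, this assay separates none of the compounds. Putting isopropyl, with no hydrogen-bond acceptor, in place of 2-methoxyethyl, with one, gives a number 9.3 percentage points lower from compound 2 to compound 3 (within the scatter), so losing the oxygen and its acceptor leaves no readable mark on this read-out, whereas the earlier step had only introduced that oxygen in place of a carbon-only stretch of chain. Putting isopropyl in place of butyl gives a number 0.3 percentage points lower from compound 1 to compound 3 (within the scatter), which shows that a branched chain cannot be told apart from a straight one here, and nothing measured alongside these numbers offers an explanation for this flat picture.

On these data alone, all three chains are small, have no ring and carry no net charge, so it remains open whether an amine or a carboxylic acid on the chain, a phenyl ring, or a much longer chain would produce a step beyond the scatter. Also open, as far as these compounds go, is whether the nitro group or the fluorine elsewhere on the shared core matters more to this read-out than the chain on this nitrogen does.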